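Adding 3-methylbut-2-en-1-yl to compound 3

This account rests on a few compounds, and the source may have more. Where it says the series, first, only, none or still open, it means among the compounds named here.

In a functional assay on U-373MG ATCC cells for inhibition, with U373 MG (Homo sapiens) as the target, read by MTT assay, with a stated time of 72 h (on this read-out lower numbers stand for stronger inhibition of growth and higher numbers for weaker inhibition of growth), compound 1 `CC(C)=CC(=O)NC(=N)N` gives > 100000 nM as its reading, which is a limit of the assay and not a number. In this assay compound 2 `C=C1CCCC(C)(C)[C@@H]1CC/C(C)=C/C(=O)NC(=N)NC(=O)C=C(C)C` gives 28800 nM and compound 3 `CC(C)=CC(=O)NC(=N)NC(=O)C=C(C)C` gives 45600 nM and these two values lie within the scatter of each other. Within the data shown here, compound 3 therefore stands level with compound 2 on the numbers available, and no pair of measured compounds differs in one place only.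

Compound 4 `CC(C)=CCC/C(C)=C/C(=O)NC(=N)NC(=O)C=C(C)C` has not yet been measured. It carries 3-methylbut-2-en-1-yl in place of hydrogen on a saturated chain carbon bound to a double-bonded chain carbon of compound 3 (3-methylbut-2-en-1-yl in place of hydrogen on a saturated chain carbon bound to a double-bonded chain carbon).

Among the measured compounds shown here, the only guide is compound 2 at 28800 nM and, since it sits within the scatter of compound 3, no step beyond the scatter is expected in this assay from this change. The estimated step is a 1.3-fold lower number from compound 3 to compound 4 (0.11 log units; within the scatter) and it is expected to stay within the scatter. For compound 4 the expected value is 35000 nM with 15000 nM to 80000 nM as the estimated range.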

Compound 4, concentration for 50% growth inhibition: 36200 nM
Compound 4: middle estimate off by 1.0-fold (0.01 log units), on the low side, and the stated range covers the measured number.
By their numbers in this assay, from the lowest: compounds 2, 4 and 3 (each within the scatter of the next). At a limit, above all of these: compound 1.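

Among these compounds, with this pair, the study gains its only comparison of compounds that differ in one place, and in this assay the change gives a 1.3-fold lower number from compound 3 to compound 4 (0.10 log units; within the scatter). Thus 3-methylbut-2-en-1-yl can take the place of hydrogen on this saturated chain carbon, bound to a double-bonded chain carbon, without a shift in the reading that stands clear of the scatter. Nothing measured here gives a cause for this result.

From the compounds shown here alone, whether an amine or a carboxylic acid at this same position would give a step beyond the scatter remains open. So does the question of whether a longer chain carrying further 3-methylbut-2-en-1-yl units would give a reading that can be told apart from that of compound 4 in this assay.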